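A few compounds are considered here, and "the series" means these few. Any claim that something is new, unique, unknown or untested is made for them only; others in the source may bear on it.

Measured compounds in a functional assay on A549 cells (Homo sapiens) for inhibition, read by MTT assay, with a stated time of 24 h; on this read-out lower numbers stand for stronger inhibition and higher numbers for weaker inhibition:
Compound 1 `CCOC(=O)C1=Cc2ccccc2OC1(OCc1cn(CC(=O)Nc2cccc(Cl)c2)nn1)C(F)(F)F` gives 12800 nM.
Compound 2 `CCOC(=O)C1=Cc2ccccc2OC1(OCc1cc(-c2ccc3ccccc3c2)no1)C(F)(F)F` reaches only the limit of the assay, > 150000 nM.
Compound 3 `O=C(O)C1=Cc2ccccc2OC1(OCc1cc(-c2ccc3ccccc3c2)no1)C(F)(F)F` likewise reaches only the limit of the assay, > 150000 nM.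

Compound 3 thus stands at the limit of > 150000 nM in this assay, at which 2 of the 3 values shown sit, with no number of its own, only a limit. Going by the values given here, the single step measured within this set, a step that the two limits leave unreadable from compound 2 to compound 3, runs between two limits, and its size cannot be read. Compound 4 `O=C(O)C1=Cc2ccccc2OC1(OCc1cc(-c2cccc(C(F)(F)F)c2)no1)C(F)(F)F` differs from compound 3 by 3-(trifluoromethyl)phenyl in place of naphthalen-2-yl on an aromatic carbon, placed on an aromatic carbon. Among the compounds with values here, no measured pair shares this exchange, so nothing among the measured steps speaks directly to it. Since compound 3 has only a limit, the step from compound 3 to compound 4 is expected to be an at least 1.5-fold lower number from compound 3 to compound 4 (0.17 log units; that floor lies within the scatter), and most likely compound 4 would again be reported as a limit rather than a number. Compound 4 is therefore estimated at 100000 nM, with a range from 30000 nM to 300000 nM.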

Compound 4, half-maximal inhibitory concentration: > 150000 nM
Compound 4 was reported as a limit (the forecaster's own chance of this, stated with the estimate: 60%); middle value at least 1.5-fold (0.17 log units) from the limit.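

Compound 3 and compound 4 both stand at a limit of this assay rather than at a number, so the step between them cannot be read. Left open is whether naphthalen-2-yl and 3-(trifluoromethyl)phenyl differ at all here, and which structural feature sets compound 1, the only compound with a number, apart.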